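Series notes: tert-butyl to 2-methoxyphenyl, kinase inhibition screen

The compounds below may be only part of what the source reports. "The series", "measured", "known", "first", "only" and "open" are said of these compounds alone.

Measured so far:
compound 1 `CC(=O)Nc1nn(C)c2cc(-c3ccccc3)[nH]c(=O)c12`: 3%
compound 2 `CC(C)(C)c1cc2nn(-c3ccccc3)c(N)c2c(=O)[nH]1`: -1%

In an assay on isolated protein for inhibition of ribosomal protein S6 kinase alpha-5 (Homo sapiens), read by mobility shift assay, tested at 30 uM (a higher number here means more inhibition at the concentration tested (going by the name of the read-out), a lower number less inhibition), compound 1 gives 3%. In this assay compound 2 gives -1%. The two numbers lie within the usual scatter of each other, so on the numbers shown compound 2 is not separated from compound 1; both read as essentially no inhibition at the concentration tested.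

Compound 3 `COc1ccccc1-c1cc2nn(-c3ccccc3)c(N)c2c(=O)[nH]1` is the next compound, not yet measured. It differs from compound 2 in one place: 2-methoxyphenyl in place of tert-butyl on an aromatic carbon. Within the data shown here, no step between two measured compounds covers this change, so its size has no precedent. Because compound 2 gives -1% and compound 1 gives 3%, both near zero, the step from compound 2 to compound 3 is expected to be small, with no direction established beyond the scatter: a number 6 percentage points higher from compound 2 to compound 3 (within the scatter). Compound 3 is estimated at 5% in this assay, with a range from -10% to 25%.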

Compound 3, a percentage reported as inhibition, at one concentration (the size of the read-out at that concentration, not a potency): 7%
The estimate for compound 3 lay 2 percentage points below the measured number; the range from low to high includes it.
By their numbers in this assay, from the lowest: compounds 2, 1 and 3 (each within the scatter of the next).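

At this aromatic carbon next to the ring nitrogen, the change to 2-methoxyphenyl in place of tert-butyl in this assay reads as a number 8 percentage points higher from compound 2 to compound 3 (within the scatter). The position therefore carries either a group with no ring or one with a six-membered aromatic ring and a hydrogen-bond acceptor without inhibition separating from the scatter, although with compound 2 at -1%, a loss could hardly be seen. Nothing available bears on a cause for this reading.

Still open, as far as these compounds go, is whether any group at this carbon, such as an amine or a carboxylic acid, lifts inhibition clear of the scatter in this assay. A plain phenyl at the same carbon would also be needed to tell the contribution of the methoxy from that of the ring.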